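The source may hold more compounds than are shown below. What is called first, only, known or untested is meant among the compounds shown, and "the series" means these compounds.

Two compounds share one core, and each carries a different aromatic group on an amide-type nitrogen. Compound 1 `N#Cc1cccc([C@]23CCC(N(CCN4CC[C@@H](O)C4)C(=O)Nc4ccccc4)CC2C3)c1` carries a plain phenyl there, and in a functional assay for antagonist activity at melanin-concentrating hormone receptor 1 (Homo sapiens) (a higher number here means a weaker inhibitor, a lower number a stronger inhibitor), compound 1 gives 132 nM. Compound 2 `N#Cc1cccc([C@]23CCC(N(CCN4CC[C@@H](O)C4)C(=O)Nc4cc(F)cc(F)c4)CC2C3)c1` carries a 3,5-difluorophenyl instead, and in this assay compound 2 gives 15 nM. Within the data shown here, the step of an 8.8-fold lower number from compound 1 to compound 2 (0.94 log units; beyond the scatter) is the only measured change so far, and it leaves compound 2 with the lower of the two numbers, that is, the stronger inhibitor of the pair.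

Compound 3 `N#Cc1cccc([C@]23CCC(N(CCN4CC[C@@H](O)C4)C(=O)Nc4cccc([N+](=O)[O-])c4)CC2C3)c1` is not yet measured. It differs from compound 2 in one place: 3-nitrophenyl in place of 3,5-difluorophenyl on an amide-type nitrogen. Among the measured compounds shown here, no measured step swaps one aromatic substituent pattern for another, so the only bearing comparison is the move from compound 1 to compound 2, where adding two fluorines to the phenyl gave an 8.8-fold lower number from compound 1 to compound 2 (0.94 log units; beyond the scatter). A single nitro group is a different change, and its effect is not known from these data. For compound 3 the expected outcome in this assay is a number between those of the two measured compounds, with the estimated step of a 2.7-fold higher number from compound 2 to compound 3 (0.43 log units; beyond the scatter) going toward a weaker inhibitor, giving an estimate of 40 nM with a range of 10 nM to 150 nM.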

Compound 3, inhibition constant: 60 nM
The estimate for compound 3 lay 1.5-fold (0.18 log units) below the measured number; the measured number falls inside the stated range.
By their numbers in this assay, from the lowest: compound 2; then compound 3; then compound 1.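

In this assay, a nitro group on the phenyl ring also gives a stronger inhibitor than the plain phenyl (a 2.2-fold lower number from compound 1 to compound 3 (0.34 log units; beyond the scatter)), so the gain at this position is not limited to the 3,5-difluorophenyl group. The gain is smaller, however, and replacing the 3,5-difluorophenyl with 3-nitrophenyl gives a weaker inhibitor (a 4.0-fold higher number from compound 2 to compound 3 (0.60 log units; beyond the scatter)), which shows that the choice of substituent on this ring matters and not only the presence of one. No supporting measurements are available to explain why the two substituted rings differ.

This last swap changes both the kind of substituent and the substitution pattern, so the compounds shown cannot separate the effect of the group from the effect of its pattern on the ring. A 3-fluorophenyl group would compare directly with both the 3,5-difluorophenyl and the 3-nitrophenyl groups, while a 3-aminophenyl or 3-carboxyphenyl group would show how far this position tolerates other kinds of substituent.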